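A few compounds are considered here, and "the series" means these few. Any claim that something is new, unique, unknown or untested is made for them only; others in the source may bear on it.

Measured so far, in an assay on CHO cells for displacement of a labelled ligand from adenosine receptor A3 (Homo sapiens), read by scintillation counting, with a stated time of 45 min, tested at 1 uM, in the presence of a further agent that is not named here; on this read-out higher numbers stand for more inhibition at the one concentration tested (going by the name of the read-out) and lower numbers for less inhibition:
- compound 1 `CCCn1c(=O)c2[nH]c(-c3ccc(S(=O)(=O)N4CCN(c5ccc(Cl)cc5)CC4)cc3)nc2n(CC)c1=O` gives 28%
- compound 2 `CCCn1c(=O)[nH]c2nc(-c3ccc(S(=O)(=O)N4CCN(c5ccc(Br)cc5)CC4)cc3)[nH]c2c1=O` gives 29%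
- compound 3 `CCCn1c(=O)[nH]c2nc(-c3ccc(S(=O)(=O)N4CCN(c5ccccc5)C(C)C4)cc3)[nH]c2c1=O` gives -2%

Compound 2 holds the largest number of the three, but compound 1 sits within the usual scatter of it, so the two are not told apart. Only compound 3 stands clearly lower, and its structure differs from compound 2 in more than one place, so that gap is not tied to any single change. Going by the values given here, with only three compounds and no pair differing in a single place, no pattern is claimed.

Compound 4 `CCCn1c(=O)[nH]c2nc(-c3ccc(S(=O)(=O)N4CCN(c5ccc(F)cc5)CC4)cc3)[nH]c2c1=O` is not yet measured. It differs from compound 2 by fluoro in place of bromo on an aromatic carbon. Since a chloro in compound 1 and a bromo in compound 2 give numbers within the scatter of each other, the expectation for the fluoro is a small step down or none beyond the scatter: the estimated step in this assay is a number 6 percentage points lower from compound 2 to compound 4 (within the scatter). Compound 4 is accordingly expected at about 23%, within a range of 6% to 38%.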

Compound 4, a percentage reported as inhibition, at one concentration (the size of the read-out at that concentration, not a potency): 38%
Compound 4: the middle estimate sits 15 percentage points below what was measured; the measured number falls inside the stated range.
By their numbers in this assay, from the lowest: compound 3; then compounds 1, 2 and 4 (each within the scatter of the next).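

In this assay, going by these compounds alone, the change from 4-bromophenyl to 4-fluorophenyl (a number 9 percentage points higher from compound 2 to compound 4 (within the scatter)) is the first step that can be read at a single place. On this aromatic carbon, para to a large group, fluoro and bromo are therefore not told apart, and exchanging one halogen for the other does not move the number beyond the scatter. No measured property of these compounds bears on this result, so no cause can be given for it.

As far as these compounds go, what a methoxy group, a nitrile or a primary amine on the same aromatic carbon would do stays open. So does the effect of having no substituent there at all, as compound 3 differs from compound 2 in more than one place.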